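The compounds below may be only part of what the source reports. "The series", "measured", "known", "first", "only" and "open" are said of these compounds alone.

Among the compounds with values here, compound 3 `CCN(Cc1ccccc1)C(=O)COc1ccc(C)cc1` stands second highest of the three numbers so far in an assay on HEK293 cells for agonist activity at transient receptor potential cation channel subfamily M member 8 (Homo sapiens), read by fluorescence and calcium flux, with a stated time of 15 min; on this read-out higher numbers stand for an effect only at larger amounts of compound and lower numbers for an effect already at smaller amounts: compound 3 gives 1880 nM, while compound 2 `CCN(Cc1ccco1)C(=O)COc1ccc(C)cc1` gives 489 nM and compound 1 `CCN(Cc1cccn1C)C(=O)COc1ccc(C)cc1` gives 21300 nM. Compound 4 `CCN(Cc1ccccn1)C(=O)COc1ccc(C)cc1` differs from compound 3 by pyridin-2-yl in place of phenyl on a saturated chain carbon bound to an amide-type nitrogen. Within the data shown here, two measured steps bear on this change at the same place: a 3.8-fold higher number from compound 2 to compound 3 (0.58 log units; beyond the scatter) and an 11-fold lower number from compound 1 to compound 3 (1.05 log units; beyond the scatter), so a ring atom other than carbon has shifted the number in either direction. For compound 4 a modest lowering beyond the scatter is expected, a 1.7-fold lower number from compound 3 to compound 4 (0.23 log units; within the scatter), leaning on the furan-2-yl comparison. Compound 4 is therefore estimated at 1100 nM, with a range from 350 nM to 3500 nM.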

Compound 4, half-maximal effective concentration: 16000 nM
Compound 4: the middle estimate sits 15-fold (1.16 log units) below what was measured, and the stated range ends below it.
By their numbers in this assay, from the lowest: compound 2; then compound 3; then compounds 4 and 1 (each within the scatter of the next).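

Moving from phenyl to pyridin-2-yl on a saturated chain carbon bound to an amide-type nitrogen gives in this assay an 8.5-fold higher number from compound 3 to compound 4 (0.93 log units; beyond the scatter) and, against the furan-2-yl compound, a 33-fold higher number from compound 2 to compound 4 (1.51 log units; beyond the scatter), so among the listed compounds only furan-2-yl improves on phenyl, with compounds 1 and 4 going the other way. The pyridin-2-yl compound shows a 1.3-fold lower number from compound 1 to compound 4 (0.12 log units; within the scatter), so compounds 1 and 4 stand level. Nothing available accounts for these shifts. From the compounds shown here alone, whether thiophen-2-yl or pyridin-3-yl would follow furan-2-yl or pyridin-2-yl remains open.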